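Working notes: methoxy in place of nitro, compound 3

A few compounds are considered here, and "the series" means these few. Any claim that something is new, unique, unknown or untested is made for them only; others in the source may bear on it.

Compound 1 `O=C(O)CCc1cn(CC(=O)NCc2ccccc2)nn1` gives 1420 uM
Compound 2 `O=C(Cn1cc(-c2cccc([N+](=O)[O-])c2)nn1)NCc1ccccc1` gives > 2000 uM

In an ADME assay on cells (spleen, Mus musculus, strain C57BL/6) for inhibition, read by flow cytometry and propidium iodide staining, with a stated time of 24 h, at 37 degrees C (on this read-out higher numbers stand for an effect only at larger amounts of compound and lower numbers for an effect already at smaller amounts), compound 2 gives > 2000 uM, which is a limit and not a number. This places compound 2 at the limit of > 2000 uM in this assay, at which 1 of the 2 values shown sits.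

Compound 3 `COc1cccc(-c2cn(CC(=O)NCc3ccccc3)nn2)c1` carries methoxy in place of nitro on an aromatic carbon, meta to a large group (methoxy in place of nitro on an aromatic carbon). Among the measured compounds shown here, no measured step covers this exchange, so no change beyond the usual scatter is expected in this assay, and neither direction is favoured. The expected step is a number no higher from compound 2 to compound 3 (the limit leaves the size open). For compound 3 the estimated value is 2000 uM, with an expected range of 1000 uM to 4000 uM.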

Compound 3, concentration for half-maximal effect: 840 uM
For compound 3 the middle estimate is 2.4-fold (0.38 log units) above the measured one; the whole stated range lies above it.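

In this assay, the aromatic carbon meta to a large group responds to this exchange: methoxy in place of nitro gives an at least 2.3-fold lower number from compound 2 to compound 3 (0.37 log units; beyond the scatter). On these data alone, its full size stays open, as compound 2 sits at a limit and not at a number: the limit of > 2000 uM in this assay, at which 1 of the 3 values shown sits. Setting 3-methoxyphenyl in place of 2-carboxyethyl gives a 1.7-fold lower number from compound 1 to compound 3 (0.23 log units; within the scatter), so that exchange does not separate the two compounds.

As far as these compounds go, whether the step follows from methoxy itself or from the loss of nitro remains open, as does how an amine or a longer alkoxy chain on that carbon would read.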